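Sulfanyl for oxy in the hydroxyethyl side chain

A few compounds are considered here, and "the series" means these few. Any claim that something is new, unique, unknown or untested is made for them only; others in the source may bear on it.

Measured so far:
Compound 1 `Cc1ccn2c(COCCO)cnc2c1` gives 200 ug/mL in a functional assay on HeLa cells (Homo sapiens) for cytotoxicity; a lower number here means that less compound is tolerated, a higher number that more compound is tolerated.
Compound 2 `OCCOCc1c(-c2ccccc2)nc2ccccn12` gives 400 ug/mL in this assay.
Compound 3 `Cc1ccn2c(CSCCO)cnc2c1` gives 10 ug/mL in this assay.

Compound 2 holds the highest of the three numbers; compound 1 lies within the scatter of it, while compound 3 sits far below both. Compound 4 `OCCSCc1c(-c2ccccc2)nc2ccccn12` is compound 2 with (2-hydroxyethyl)sulfanyl in place of 2-hydroxyethoxy on a saturated chain carbon bound to an aromatic carbon. Among the measured compounds shown here, the one measured step carrying the same change is a 20-fold lower number from compound 1 to compound 3 (1.30 log units; beyond the scatter), a large drop well beyond the scatter. On that single precedent, a step of similar size and direction is expected, a 20-fold lower number from compound 2 to compound 4 (1.30 log units; beyond the scatter), in this assay. For the measured compounds named here, compound 4 is therefore estimated at 20 ug/mL, within a range of 5 ug/mL to 80 ug/mL, with the width reflecting that only one such step, from compound 1 to compound 3, is known.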

Compound 4, minimum cytotoxic concentration: > 100 ug/mL
Compound 4: a limit, no number; the forecaster's own chance of this, stated with the estimate: 5%; at least 5.0-fold (0.69 log units) between middle value and limit.
By their numbers in this assay, from the lowest: compound 3; then compounds 1 and 2 (each within the scatter of the next).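

In this assay, among the compounds shown here, compound 4 gives > 100 ug/mL, a limit and not a number, so no step from compound 2 to compound 4 can be read. Going by these compounds, whether (2-hydroxyethyl)sulfanyl in place of 2-hydroxyethoxy lowers the number on the core of compound 2, as it does on that of compound 1, stays open.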